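Dropping One Chlorine from a Flavone Arylsulfone

The source may hold more compounds than are shown below. What is called first, only, known or untested is meant among the compounds shown, and "the series" means these compounds.

Compound 1, `CS(=O)(=O)c1ccc(-c2oc3ccccc3c(=O)c2-c2cc(Cl)cc(Cl)c2)cc1`: < 5%
Compound 2, `CSc1ccc(-c2c(-c3ccc(S(N)(=O)=O)cc3)oc3ccccc3c2=O)cc1`: 90%

Two compounds carry measured values in an assay on isolated protein for inhibition of prostaglandin G/H synthase 1 (Mus musculus), tested at 10 ug/mL; on this read-out higher numbers stand for more inhibition at the one concentration tested (going by the name of the read-out) and lower numbers for less inhibition. In this assay compound 1 gives < 5%, which is a limit and not a number. Compound 1 therefore stands at the limit of < 5% in this assay, at which 1 of the 2 values shown sits. In this assay compound 2 gives 90%, and of the two values shown it is the higher one. Going by the values given here, no step between compound 1 and compound 2 is set out, as they differ in more than one place, so the two values can only be read side by side.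

Compound 3, `CS(=O)(=O)c1ccc(-c2oc3ccccc3c(=O)c2-c2ccc(Cl)cc2)cc1`, is not yet measured. It differs from compound 1 in a single place: 4-chlorophenyl in place of 3,5-dichlorophenyl on an aromatic carbon. With compound 1 at a limit, the size of any step is hard to fix; the step from compound 1 to compound 3 is expected to be a number at least 10 percentage points higher from compound 1 to compound 3 (that floor lies within the scatter), upward but modest, and it may well stay within the scatter. For compound 3 the estimated value in this assay is 15%, within a range from 0% to 45%, with a real chance that only a limit is reported again.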

Compound 3, a percentage reported as inhibition, at one concentration (the size of the read-out at that concentration, not a potency): < 5%
Compound 3 ended at the assay's limit; the forecaster's own chance of this, stated with the estimate: 40%; middle value at least 10 percentage points away from the limit.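

In this assay compound 3 gives < 5% and that is a limit, not a number. Going by these compounds alone, compound 1 also stands at a limit, so no step between compound 1 and compound 3 can be read: the limit of < 5% in this assay, at which 2 of the 3 values shown sit. The compounds shown leave open whether 4-chlorophenyl and 3,5-dichlorophenyl differ at all in this read-out beneath that limit.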